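The source may hold more compounds than are shown below. What is called first, only, known or untested is meant among the compounds shown, and "the series" means these compounds.

Compound 1 `O=C(CCc1cccc2c1B(O)OC2)Nc1ccc(F)cc1`: 720 nM
Compound 2 `O=C(CCc1cccc2c1B(O)OC2)Nc1ccc2ccccc2c1`: 1400 nM

In a functional assay on SK-OV-3 cells (Homo sapiens) for antiproliferative activity, read by MTT assay, with a stated time of 72 h (a higher number here means a weaker inhibitor, a lower number a stronger inhibitor), compound 1 gives 720 nM, the lowest of the two numbers, while compound 2 gives 1400 nM, which lies within the scatter of it. Compound 3 `O=C(CCc1cccc2c1B(O)OC2)Nc1ccc(-c2ccccc2)cc1` differs from compound 1 by phenyl in place of fluoro on an aromatic carbon. For the measured compounds named here, no step between measured compounds is available for this change; the two values of compound 1 and compound 2 show only that a larger aromatic amide substituent did not move the number beyond the scatter. The expected step is a 1.7-fold higher number from compound 1 to compound 3 (0.22 log units; within the scatter), small and, if anything, toward a higher number. Compound 3 is therefore estimated at 1200 nM, with a range from 400 nM to 3600 nM.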

Compound 3, half-maximal inhibitory concentration: 48000 nM
Estimate against measurement, compound 3: 40-fold (1.60 log units) below; measured number outside the range, above it.
By their numbers in this assay, from the lowest: compounds 1 and 2 (each within the scatter of the next); then compound 3.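

In this assay, phenyl in place of fluoro on an aromatic carbon, para to a large group, gives a 67-fold higher number from compound 1 to compound 3 (1.82 log units; beyond the scatter). This shows that the number at this position is highly sensitive to the group placed there, and that adding an aromatic ring here can cost much of the activity. Nothing available explains the step. As far as these compounds go, whether chloro, methoxy, an amine or a carboxylic acid on this carbon would stay near compound 1 or move toward compound 3 remains open.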